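Hydroxylated Amide Variant on a Second Core

The compounds below may be only part of what the source reports. "The series", "measured", "known", "first", "only" and "open" are said of these compounds alone.

Compound 1 `COc1c(F)ccc2c1c(NS(=O)(=O)c1ccc(Cl)s1)nn2Cc1cccc(CNC(C)=O)c1` is measured in a functional assay on CHO cells for antagonist activity at C-C chemokine receptor type 4 (Homo sapiens), read by GTPgammaS binding (a lower number here means a stronger inhibitor, a higher number a weaker inhibitor), where compound 1 gives 12.6 nM. Compound 2 `COc1c(F)ccc2c1c(NS(=O)(=O)c1ccc(Cl)s1)nn2Cc1cccc(CNC(=O)C(C)(C)O)c1` carries 1-hydroxy-1-methylethyl in place of methyl on a carbonyl carbon; in this assay compound 2 gives 39.8 nM, and the step of a 3.2-fold higher number from compound 1 to compound 2 (0.50 log units; beyond the scatter) is modest but beyond the scatter. Compound 3 `COc1cc(F)cc2c1c(NS(=O)(=O)c1ccc(Cl)s1)nn2Cc1cccc(CNC(C)=O)c1` has the same atoms as compound 1 joined differently; the difference between the two cores is not broken down here. In this assay compound 3 gives 39.8 nM, level with compound 2 at the digits printed. Compound 4 `COc1cc(F)cc2c1c(NS(=O)(=O)c1ccc(Cl)s1)nn2Cc1cccc(CNC(=O)C(C)(C)O)c1` is not yet measured and differs from compound 3 by 1-hydroxy-1-methylethyl in place of methyl on a carbonyl carbon, the same change as that between compound 1 and compound 2, at the same place. Among the measured compounds shown here, for compound 4 the expected step in this assay is a 2.8-fold higher number from compound 3 to compound 4 (0.44 log units; beyond the scatter), resting on the single earlier step of a 3.2-fold higher number from compound 1 to compound 2 (0.50 log units; beyond the scatter). Compound 4 is therefore estimated at 110 nM in this assay, between 40 nM and 320 nM.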

Compound 4, half-maximal inhibitory concentration in the C-C chemokine receptor type 4 assay: 15.9 nM
Compound 4: middle estimate off by 6.9-fold (0.84 log units), on the high side, outside the stated range (below it).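

On the second core, 1-hydroxy-1-methylethyl in place of methyl on a carbonyl carbon gives, in the C-C chemokine receptor type 4 assay, a 2.5-fold lower number from compound 3 to compound 4 (0.40 log units; beyond the scatter); compound 3 gives 39.8 nM and compound 4 gives 15.9 nM. The effect of this change therefore does not carry over from one core to the other, not even in direction: the same change on two cores in the C-C chemokine receptor type 4 assay, a 3.2-fold higher number (0.50 log units; beyond the scatter) from compound 1 to compound 2 and a 2.5-fold lower number (0.40 log units; beyond the scatter) from compound 3 to compound 4, 7.9-fold (0.90 log units) apart, beyond the scatter of two such steps This shows that the step depends on the core in these two pairs, but two pairs give no rule for other cores and do not show what in the cores accounts for the difference.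

In a physicochemical assay for acid dissociation, compound 3 gives "not determined" (no result reported) and compound 4 gives "not determined" (no result reported), so no step can be read there. As far as these compounds go, it also remains open whether an amine or a carboxylic acid in place of the hydroxyl, or a longer chain on the carbonyl carbon, would follow the pattern of the first core or the second.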